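Cytotoxicity notes: cyclopropyl in place of 3-bromobenzyl

A few compounds are considered here, and "the series" means these few. Any claim that something is new, unique, unknown or untested is made for them only; others in the source may bear on it.

- compound 1 `COc1ccc(Cn2c(C(=O)N3CCCCC3)cc3sccc32)cc1` gives > 100000 nM as a limit
- compound 2 `COc1ccc(Cn2c(C(=O)N3CCC(C(=O)NCc4cccc(Br)c4)CC3)cc3sccc32)cc1` gives > 100000 nM as a limit

In an ADME assay on HEK-293T cells (Homo sapiens) for cytotoxicity, read by luminescence, with a stated time of 24 h (on this read-out lower numbers stand for higher toxicity in this test and higher numbers for lower toxicity in this test), compound 2 reads > 100000 nM as a limit and not as a number. The two measured compounds share the limit of > 100000 nM in this assay, at which 2 of the 2 values shown sit, and so cannot be ranked.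

The next compound, compound 3 `COc1ccc(Cn2c(C(=O)N3CCC(C(=O)NC4CC4)CC3)cc3sccc32)cc1`, has cyclopropyl in place of 3-bromobenzyl on an amide-type nitrogen.

Going by the values given here, the one measured step that bears on this change is a step that the two limits leave unreadable from compound 1 to compound 2 and it offers no size to carry over. Among the compounds with values here, with that step as the only guide, no shift beyond the scatter is expected for compound 3 in this assay and a limit reading is likely.

The estimated step is a number no higher from compound 2 to compound 3 (the limit leaves the size open) and it is expected to stay within the scatter. The estimate for compound 3 is 100000 nM with an expected range of 60000 nM to 150000 nM on this read-out.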

Compound 3, half-maximal cytotoxic concentration: 21400 nM
Beside the measured number, compound 3's estimate is 4.7-fold (0.67 log units) above it; measured number below the stated range.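

Compound 3 is the only compound shown that gives a number in this assay, so a change on this amide-type nitrogen can register on this read-out: cyclopropyl in place of 3-bromobenzyl gives an at least 4.6-fold lower number from compound 2 to compound 3 (0.66 log units; beyond the scatter). Cyclopropylcarbamoyl in place of hydrogen on the saturated ring carbon gives an at least 4.6-fold lower number from compound 1 to compound 3 (0.66 log units; beyond the scatter), while the step from compound 1 to compound 2 cannot be read. The full size of both readable steps stays open because the other two compounds sit at a limit: the limit of > 100000 nM in this assay, at which 2 of the 3 values shown sit.

The compounds shown leave open whether the lower number belongs to cyclopropyl itself or would also appear with any small group on this nitrogen. A methyl, a cyclobutyl or a plain benzyl at the same place would separate these readings.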